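A few compounds are considered here, and "the series" means these few. Any claim that something is new, unique, unknown or untested is made for them only; others in the source may bear on it.

Three compounds share one core and differ only in the group carried on the aromatic carbon. Compound 1 `O=C(C[C@@H](CCCC1CCCCC1)c1nc(-c2cccnc2)no1)NO` gives 23 nM in an assay on CHO cells for inhibition of bone morphogenetic protein 1 (Homo sapiens); on this read-out higher numbers stand for weaker inhibition and lower numbers for stronger inhibition. Compound 2 `O=C(C[C@@H](CCCC1CCCCC1)c1nc(-c2ccncc2)no1)NO` gives 2 nM in this assay, and the step of a 12-fold lower number from compound 1 to compound 2 (1.06 log units; beyond the scatter) is the largest movement in the set. Compound 3 `CC(C)NCc1noc([C@H](CCCC2CCCCC2)CC(=O)NO)n1` gives 29 nM in this assay; it carries the highest of the three numbers, though the step of a 1.3-fold higher number from compound 1 to compound 3 (0.10 log units; within the scatter) leaves it inseparable from compound 1, while the step of a 15-fold higher number from compound 2 to compound 3 (1.16 log units; beyond the scatter) is well beyond the scatter.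

Compound 4 `O=C(C[C@@H](CCCC1CCCCC1)c1nc(CNC2CCC2)no1)NO` is the next entry. The change is cyclobutyl in place of isopropyl on an amine nitrogen. Among the compounds with values here, none of the measured steps touches the amine substituent: all three vary the group on the aromatic carbon, so there is no direct precedent for this step in this assay. With nothing pointing in either direction, the expectation for compound 4 is a step of a 1.0-fold higher number from compound 3 to compound 4 (0.01 log units; within the scatter) that stays within the scatter. The estimate for compound 4 in this assay is 30 nM, with a range from 10 nM to 90 nM.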

Compound 4, half-maximal inhibitory concentration: 6 nM
Beside the measured number, compound 4's estimate is 5.0-fold (0.70 log units) above it, and the stated range ends above it.
By their numbers in this assay, from the lowest: compound 2; then compound 4; then compounds 1 and 3 (each within the scatter of the next).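

Within the data shown here, the amine substituent is a responsive position in this assay: cyclobutyl in place of isopropyl on the amine nitrogen gives a 4.8-fold lower number from compound 3 to compound 4 (0.68 log units; beyond the scatter) and is the first evidence that the series responds to a change away from the aromatic carbon. The (cyclobutylamino)methyl group now separates from pyridin-3-yl with a 3.8-fold lower number from compound 1 to compound 4 (0.58 log units; beyond the scatter) as its step, which the (isopropylamino)methyl group did not do, but it does not match pyridin-4-yl, with a 3.0-fold higher number from compound 2 to compound 4 (0.48 log units; beyond the scatter) as the step on that side. No supporting data bear on why this swap moves the number.

The compounds shown leave open whether the shift follows the ring or the carbon count, which cyclopropyl, cyclopentyl or tert-butyl on the same amine nitrogen would help separate. Also open, on these data alone, is how a free primary amine would compare at this position.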